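Moving the Amide Around a Pyridine Ring

A few compounds are considered here, and "the series" means these few. Any claim that something is new, unique, unknown or untested is made for them only; others in the source may bear on it.

Among the compounds with values here, compound 3 `COc1ccc(-c2cc(C(=O)N(C)C)ccn2)cc1S(=O)(=O)Nc1cccc(NCCNC(=O)c2cccc(C)c2)c1` holds the higher of the two numbers known in a functional assay on CHO-RD-HGA16 cells for agonist activity at Orexin/Hypocretin receptor type 1 (Homo sapiens), read by fluorescence and calcium flux, with a stated time of 30 min; on this read-out lower numbers stand for an effect already at smaller amounts and higher numbers for an effect only at larger amounts of compound: compound 3 gives 1810 nM. Compound 1 `COc1ccc(-c2cccc(C(=O)N(C)C)c2)cc1S(=O)(=O)Nc1cccc(NCC(C)NC(=O)c2cccc(C)c2)c1` gives 666 nM, a lower number by a gap beyond the scatter. Compound 2 `COc1ccc(-c2cccc(C(=O)N(C)C)c2)cc1S(=O)(=O)Nc1cccc(N2CCN(C(=O)c3cccc(C)c3)CC2)c1` sits at the limit of > 10000 nM in this assay, at which 1 of the 3 values shown sits, and its value > 10000 nM is a limit and not a number. Compound 4 `COc1ccc(-c2cccc(C(=O)N(C)C)n2)cc1S(=O)(=O)Nc1cccc(NCCNC(=O)c2cccc(C)c2)c1` differs from compound 3 in one place: 6-(dimethylcarbamoyl)pyridin-2-yl in place of 4-(dimethylcarbamoyl)pyridin-2-yl on an aromatic carbon. Within the data shown here, no measured pair shows this rearrangement, so the size of the step in this assay is open; one expects a modest move toward a higher number, or none beyond the scatter. Compound 4 is estimated at 3000 nM, within 900 nM to 10000 nM. The expected step is a 1.7-fold higher number from compound 3 to compound 4 (0.22 log units; within the scatter).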

Compound 4, half-maximal effective concentration: 226 nM
Estimate against measurement, compound 4: 13-fold (1.12 log units) above; measured number below the stated range.
By their numbers in this assay, from the lowest: compound 4; then compound 1; then compound 3. At a limit, above all of these: compound 2.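

In this assay, placing 6-(dimethylcarbamoyl)pyridin-2-yl in place of 4-(dimethylcarbamoyl)pyridin-2-yl gives an 8.0-fold lower number from compound 3 to compound 4 (0.90 log units; beyond the scatter). The earlier compounds shown here held no pair differing in one place, and this one shows that rearranging the same atoms at this aromatic carbon, with the counted features unchanged, is enough to move the number beyond the scatter. Nothing measured here gives a cause for this step. Going by these compounds, whether a carboxylic acid or an amine in place of the dimethylcarbamoyl group would keep the lower number remains open. So does whether the same rearrangement carries over to the chain of compound 1.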